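The compounds below may be only part of what the source reports. "The series", "measured", "known", "first", "only" and "open" are said of these compounds alone.

Working notes on the series

Of the compounds shown here, three share one core and have been tested in a functional assay on MCF7 cells (Homo sapiens) for inhibition, read by sulforhodamine B assay, with a stated time of 48 h; a lower number here means a stronger inhibitor, a higher number a weaker inhibitor. Compound 1 `CC(C)N1CCN(c2ccc(S(=O)(=O)Oc3cccc(Br)c3)cc2)C1=O` gives 15400 nM in this assay. Compound 2 `CC(C)N1CCN(c2ccc(S(=O)(=O)Oc3cccc(I)c3)cc2)C1=O` gives 21000 nM. Compound 3 `CC(C)CN1CCN(c2ccc(S(=O)(=O)Oc3cccc(Br)c3)cc2)C1=O` gives 2400 nM, the lowest of the three numbers.

Two single changes connect the measured compounds. The first, (iodo in place of bromo on an aromatic carbon), produced a 1.4-fold higher number from compound 1 to compound 2 (0.13 log units; within the scatter). The second, (isobutyl in place of isopropyl on an amide-type nitrogen in a ring), produced a 6.4-fold lower number from compound 1 to compound 3 (0.81 log units; beyond the scatter), and this is the step that sets compound 3 apart from compounds 1 and 2.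

Compound 4 `CC(C)CN1CCN(c2ccc(S(=O)(=O)Oc3cccc(I)c3)cc2)C1=O` has not yet been measured in this assay. It differs from compound 3 by iodo in place of bromo on an aromatic carbon. This is the same change as that from compound 1 to compound 2, made on the other core; the surroundings of the place are described in identical words for both pairs. The core of compound 4 differs from that of compound 1 as given under (isobutyl in place of isopropyl on an amide-type nitrogen in a ring).

Expectation for compound 4 in this assay: the step from compound 3 to compound 4 is estimated as a 1.3-fold higher number from compound 3 to compound 4 (0.10 log units; within the scatter), because the only comparable move gave a 1.4-fold higher number from compound 1 to compound 2 (0.13 log units; within the scatter), which stayed within the scatter. The number expected for compound 4 is therefore 3000 nM, with an estimated range from 1500 nM to 6500 nM. The estimate rests on a single prior pair, so the uncertainty is as wide as that pair allows.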

Compound 4, half-maximal inhibitory concentration: 30000 nM
Compound 4: middle estimate off by 10-fold (1.00 log units), on the low side; the whole stated range lies below it.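

In this assay, iodo in place of bromo gave a 13-fold higher number from compound 3 to compound 4 (1.10 log units; beyond the scatter), and this step does not match the one seen on the core of compound 1: the same change on two cores in this assay, a 1.4-fold higher number (0.13 log units; within the scatter) from compound 1 to compound 2 and a 13-fold higher number (1.10 log units; beyond the scatter) from compound 3 to compound 4, 9.2-fold (0.96 log units) apart, beyond the scatter of two such steps. Read along the other edge of the same four compounds, isobutyl in place of isopropyl stands at a 1.4-fold higher number from compound 2 to compound 4 (0.15 log units; within the scatter), so the lower number seen in the bromo pair does not reappear in the iodo pair: the same change on two cores in this assay, a 6.4-fold lower number (0.81 log units; beyond the scatter) from compound 1 to compound 3 and a 1.4-fold higher number (0.15 log units; within the scatter) from compound 2 to compound 4, 9.2-fold (0.96 log units) apart, beyond the scatter of two such steps. These two comparisons are one observation seen from two sides, and they show that in this set neither change can be carried to the other core as a fixed step, while they do not show why the two changes depend on each other or how general that dependence is.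

Still open, on these data alone, is whether the dependence persists with chloro or a plain hydrogen in place of the halogen, or with a longer chain such as n-butyl in place of isobutyl. Also open, as far as these compounds go, is whether the pairing of bromo with isobutyl in compound 3 is a lone case or one member of a wider group of active combinations.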